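Bromo for Chloro on the Thiophene of Compound 1

The compounds below may be only part of what the source reports. "The series", "measured", "known", "first", "only" and "open" are said of these compounds alone.

Compound 1 `C[C@H]1[C@H](NCc2ccc(Cl)s2)C[C@H]2C[C@@H]1C2(C)C` is one of three close relatives examined in an ADME assay on MDCK cells (Canis lupus familiaris) for cytotoxicity, read by microscopy, with a stated time of 48 h (on this read-out higher numbers stand for lower toxicity in this test and lower numbers for higher toxicity in this test), where compound 1 gives 25000 nM. Its companions are compound 2 `CCOc1ccsc1CN[C@@H]1C[C@H]2C[C@@H]([C@H]1C)C2(C)C`, which gives 50000 nM, and compound 3 `CCCCc1ccsc1CN[C@@H]1C[C@H]2C[C@@H]([C@H]1C)C2(C)C`, which gives 25000 nM. As the numbers stand, compound 1 is level with compound 3, the two together being the lowest of the three, and compound 2 sits a little higher, but all three lie within the scatter of one another. Among the compounds with values here, the only single-point step measured so far is a 2.0-fold lower number from compound 2 to compound 3 (0.30 log units; within the scatter), a change of butyl in place of ethoxy on an aromatic carbon, and it did not move the read-out beyond the scatter.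

Compound 4 `C[C@H]1[C@H](NCc2ccc(Br)s2)C[C@H]2C[C@@H]1C2(C)C` differs from compound 1 as follows: bromo in place of chloro on an aromatic carbon. Within the data shown here, no measured step swaps one halogen for another, so the step from compound 2 to compound 3 is the only guide, and it suggests that an even smaller change on the same ring should leave the read-out essentially where it is. Compound 4 is therefore expected to give 25000 nM, with a range from 12500 nM to 50000 nM. The expected step is no change at the digits printed from compound 1 to compound 4 (within the scatter), nothing beyond the scatter.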

Compound 4, minimum cytotoxic concentration: 43000 nM
Beside the measured number, compound 4's estimate is 1.7-fold (0.24 log units) below it; the measured number falls inside the stated range.
By their numbers in this assay, from the lowest: compounds 1, 3, 4 and 2 (each within the scatter of the next).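

With the 5-chlorothiophen-2-yl group changed to 5-bromothiophen-2-yl, on the aromatic carbon next to the ring sulfur, this assay shows a 1.7-fold higher number from compound 1 to compound 4 (0.24 log units; within the scatter). This is the one halogen exchange among the compounds shown, and it gives a direct reading at a place untouched by the ethoxy-to-butyl step: at this position, the read-out does not separate bromo from chloro. Nothing available here offers an explanation for the size of this step.

The compounds leave open whether a group of a different kind on this same carbon, such as a carboxylic acid or an amine, would carry the read-out beyond the scatter. On these data alone, it also remains open whether a longer chain or a methoxy group there would leave the number as undisturbed as the two halogens do.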